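One Added Methyl and a Cytotoxicity Reading

A few compounds are considered here, and "the series" means these few. Any claim that something is new, unique, unknown or untested is made for them only; others in the source may bear on it.

Three related compounds have been measured in a functional assay on SK-MEL-28 cells (Homo sapiens) for cytotoxicity (on this read-out lower numbers stand for stronger inhibition and higher numbers for weaker inhibition), so far. Compound 1 `CC(=O)Oc1ccc(OC(C)=O)c2c1CC=C(CCC=C(C)C)C2` gives 3600 nM as its reading, and compound 2 `CC(C)=CCCC1=CCc2c(O)cc(C)c(O)c2C1` gives 19400 nM as its reading. Compound 3 `CC(C)=CCCC1=CCC2=C(C1)C(=O)C=CC2=O` gives 2100 nM as its reading, which lies within the usual scatter of compound 1 and well below compound 2.

Compound 4 `CC(C)=CCCC1=CCC2=C(C1)C(=O)C(C)=CC2=O` is compound 3 with a single edit. The change is methyl in place of hydrogen on a double-bonded ring carbon and amounts to a methyl in place of hydrogen on a double-bonded ring carbon of a six-membered non-aromatic ring of carbon only.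

For the measured compounds named here, no two measured compounds differ in just one place, so nothing yet shows what one such edit does in this assay on its own. Compound 2 also carries a methyl on its core and reads 19400 nM as its value, but it differs from compound 3 in more than that methyl, so this gap says little about the new edit. The expected step of a 1.1-fold higher number from compound 3 to compound 4 (0.06 log units; within the scatter) is small and stays within the scatter, and the data support no firm direction. For compound 4 the estimate is 2400 nM with an expected range from 900 nM to 6500 nM on this read-out.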

Compound 4, half-maximal inhibitory concentration: 9800 nM
The estimate for compound 4 lay 4.1-fold (0.61 log units) below the measured number; the measured number lies above the stated range.
By their numbers in this assay, from the lowest: compounds 3 and 1 (each within the scatter of the next); then compounds 4 and 2 (each within the scatter of the next).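

In this assay, for the compounds shown here, the change from hydrogen to methyl gives the first reading of what a single edit does, and a 4.7-fold higher number from compound 3 to compound 4 (0.67 log units; beyond the scatter) is a step beyond the scatter, toward weaker inhibition. This position on a double-bonded ring carbon of a six-membered non-aromatic ring of carbon only is therefore not indifferent to substitution, since a single methyl there is enough to shift the reading clearly, although this rests on one pair of compounds and sets no general rule. The result shows only the size and direction of the step, and nothing available here explains why the reading moved.

Still open, from the compounds shown here alone, is whether the step follows from a methyl in particular, or whether a longer chain such as ethyl, a methoxy group, a chlorine atom or an amine on the same ring carbon would move the reading by a similar amount, by less, or the other way. Also open, going by these compounds, is whether the same methyl would produce a comparable step on the core of compound 1, whose ring differs from that of compound 3.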